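Swapping an aryl for a cyclopentyl on the amide

This account rests on a few compounds, and the source may have more. Where it says the series, first, only, none or still open, it means among the compounds named here.

For the measured compounds named here, compound 2 `COc1cc(OC)cc(C(=O)Nc2cc(-c3ccccc3)nn2-c2ccccc2)c1` gives 2040 nM in a functional assay on cells for positive allosteric modulation of metabotropic glutamate receptor 5 (Rattus norvegicus), read by calcium flux (on this read-out lower numbers stand for an effect already at smaller amounts and higher numbers for an effect only at larger amounts of compound), the higher of the two numbers known here; compound 1 `O=C(Nc1cc(-c2ccccc2)nn1-c1ccccc1)c1cccc([N+](=O)[O-])c1` gives 39 nM, and the step of a 52-fold higher number from compound 1 to compound 2 (1.72 log units; beyond the scatter) shows how strongly the group on the carbonyl carbon moves this read-out. Compound 3 `O=C(Nc1cc(-c2ccccc2)nn1-c1ccccc1)C1CCCC1` carries cyclopentyl in place of 3,5-dimethoxyphenyl on a carbonyl carbon. Going by the values given here, only that single step bears on the change, and it concerns a different entering group, so no direct precedent exists. The estimate for compound 3 is an expected step of a 1.5-fold higher number from compound 2 to compound 3 (0.17 log units; within the scatter), with a value of 3000 nM between 500 nM and 20000 nM.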

Compound 3, half-maximal effective concentration: 3410 nM
For compound 3 the middle estimate is 1.1-fold (0.06 log units) below the measured one, and the stated range covers the measured number.
By their numbers in this assay, from the lowest: compound 1; then compounds 2 and 3 (each within the scatter of the next).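

Putting cyclopentyl on the carbonyl carbon, with 5 heavy atoms and no hydrogen-bond acceptors, leaves compound 3 within the scatter of compound 2 (a 1.7-fold higher number from compound 2 to compound 3 (0.22 log units; within the scatter)), so swapping the 3,5-dimethoxyphenyl for this non-aromatic ring makes no measurable difference here. The distance from the 3-nitrophenyl compound remains large (an 87-fold higher number from compound 1 to compound 3 (1.94 log units; beyond the scatter)), which leaves compound 1 alone at the low end among these three. Nothing available here explains this pattern.

Still open, from the compounds shown here alone, is whether a plain phenyl or a 3-cyanophenyl on the carbonyl carbon would read closer to compound 1 or to compound 3.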